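The source may report more compounds than this note shows. Statements on the series, on what has been measured and on what is new or still open speak of the compounds shown alone.

Measured compounds in this series:

Compound 1, `CC(C)c1onc(-c2c(Cl)cccc2Cl)c1COc1ccc(-c2nc3ccc(C(=O)O)cc3n2CC2CC2)cc1`: 2650 nM
Compound 2, `CC(C)c1onc(-c2c(Cl)cccc2Cl)c1COc1ccc(-c2nc3ccc(C(=O)O)cc3n2C2CCCCCC2)cc1`: 921 nM
Compound 3, `CC(C)c1onc(-c2c(Cl)cccc2Cl)c1COc1ccc(-c2nc3ccc(C(=O)O)cc3n2C2CCCCC2)cc1`: 1450 nM

All three share one core and differ only in the group on the aromatic nitrogen. In an assay on HEK-293T cells for antagonist activity at vitamin D3 receptor (Homo sapiens), read by a luciferase reporter, with a stated time of 24 h (a higher number here means a weaker inhibitor, a lower number a stronger inhibitor), compound 3 gives 1450 nM, the second highest of the three numbers; its nearest neighbour is compound 2, and the gap a 1.6-fold higher number from compound 2 to compound 3 (0.20 log units; within the scatter) is within the scatter, as is the gap a 1.8-fold lower number from compound 1 to compound 3 (0.26 log units; within the scatter) to compound 1. Within the data shown here, the only step beyond the scatter is a 2.9-fold lower number from compound 1 to compound 2 (0.46 log units; beyond the scatter).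

Compound 4, `CC(=O)C1CCC(Cn2c(-c3ccc(OCc4c(-c5c(Cl)cccc5Cl)noc4C(C)C)cc3)nc3ccc(C(=O)O)cc32)CC1`, is not yet measured. It differs from compound 3 by the change ((4-acetylcyclohexyl)methyl in place of cyclohexyl on an aromatic nitrogen).

The measured steps bear on the new compound only in part: they show that exchanging one saturated carbocyclic group for another on this nitrogen moves this assay modestly at most, and none of them introduces a carbonyl on that group. Among the measured compounds shown here, no step therefore speaks directly to the acetyl. On this basis the step of a 1.2-fold lower number from compound 3 to compound 4 (0.08 log units; within the scatter) is expected to stay within or just beyond the scatter, without a firm direction. Compound 4 is estimated at 1200 nM, with a range of 400 nM to 3500 nM.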

Compound 4, half-maximal inhibitory concentration: > 10000 nM
Compound 4: a limit, no number (the forecaster's own chance of this, stated with the estimate: 10%); at least 8.3-fold (0.92 log units) between middle value and limit.
By their numbers in this assay, from the lowest: compounds 2, 3 and 1 (each within the scatter of the next, the first and the last beyond it). At a limit, above all of these: compound 4.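

Compound 4 stands at a limit of the assay and not at a number: the limit of > 10000 nM in this assay, at which 1 of the 4 values shown sits. On the aromatic nitrogen, cyclopropylmethyl, cyclohexyl and cycloheptyl all keep a measurable value, while (4-acetylcyclohexyl)methyl does not, so this position does not tolerate every saturated carbocyclic group: the read-out shows an at least 6.8-fold higher number from compound 3 to compound 4 (0.83 log units; beyond the scatter), an at least 10-fold higher number from compound 2 to compound 4 (1.03 log units; beyond the scatter) and an at least 3.7-fold higher number from compound 1 to compound 4 (0.57 log units; beyond the scatter). Among these compounds, each of these steps is bounded on one side only, so the loss in this assay has a minimum size but no known full size, and it exceeds the only step beyond the scatter among the earlier compounds, a 2.9-fold lower number from compound 1 to compound 2 (0.46 log units; beyond the scatter).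

The change adds a saturated chain carbon and an acetyl group together, so the compounds shown do not separate the two, and the plain cyclohexylmethyl group would be the direct test of which one carries the loss. Also open, as far as these compounds go, is whether the acetyl carbonyl itself matters or any substituent at that ring carbon does the same, which a hydroxyl, an amine or a carboxylic acid in place of the acetyl would address.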